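Replacing One Benzoyl Group with a Butyl Chain

A few compounds are considered here, and "the series" means these few. Any claim that something is new, unique, unknown or untested is made for them only; others in the source may bear on it.

For the measured compounds named here, the three compounds measured so far share one core and differ only in the aromatic group attached to one of their two carbonyl carbons. Compound 1 `CC(C)(C)N(NC(=O)c1ccccc1)C(=O)c1ccccc1F` gives 309 nM in an assay on cells for agonist activity at ecdysone receptor (Bombyx mori), read by a luciferase reporter, with a stated time of 24 h; on this read-out higher numbers stand for an effect only at larger amounts of compound and lower numbers for an effect already at smaller amounts. Compound 2 `CCc1ccccc1C(=O)N(NC(=O)c1ccccc1)C(C)(C)C` gives 589 nM, and the step of a 1.9-fold higher number from compound 1 to compound 2 (0.28 log units; within the scatter) lies within the scatter. Compound 3 `Cc1cc(C)cc(C(=O)N(NC(=O)c2ccccc2)C(C)(C)C)c1` gives 69.2 nM, the lowest of the three numbers; the steps of a 4.5-fold lower number from compound 1 to compound 3 (0.65 log units; beyond the scatter) and an 8.5-fold lower number from compound 2 to compound 3 (0.93 log units; beyond the scatter) are both beyond the scatter, so compound 3 stands apart from the other two.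

Compound 4 `CCCCC(=O)NN(C(=O)c1cc(C)cc(C)c1)C(C)(C)C` has not yet been measured. It differs from compound 3 at the other carbonyl carbon: butyl in place of phenyl on a carbonyl carbon. Going by the values given here, none of the measured steps touches this carbonyl; all three exchange groups on the carbonyl carbon that carries the 3,5-dimethylphenyl group in compound 3, and even the largest of them was modest. The data therefore give no direct guide for removing an aromatic ring altogether in favour of a chain, and the expectation is uncertain. A step of a 22-fold higher number from compound 3 to compound 4 (1.34 log units; beyond the scatter) toward a higher number is expected. Compound 4 is accordingly estimated at 1500 nM, with a range from 300 nM to 8000 nM.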

Compound 4, half-maximal effective concentration: 1860 nM
Compound 4: middle estimate off by 1.2-fold (0.09 log units), on the low side; low and high end bracket the measured number.
By their numbers in this assay, from the lowest: compound 3; then compounds 1 and 2 (each within the scatter of the next); then compound 4.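

In this assay, this is the first change shown at the carbonyl carbon that holds the phenyl group, and the step is large: a 27-fold higher number from compound 3 to compound 4 (1.43 log units; beyond the scatter). For the compounds shown here, all the earlier steps lay on the other carbonyl carbon, where the biggest was an 8.5-fold lower number from compound 2 to compound 3 (0.93 log units; beyond the scatter), so the new result shows that the number also responds strongly to a change at this second carbonyl carbon, here the exchange of an aromatic ring for butyl, a chain with no ring. Nothing available explains why the number rises with this exchange.

With a single exchange shown at this position, it remains open whether the higher number goes with the loss of the aromatic ring or with butyl in particular, and a longer chain such as hexyl, a non-aromatic ring such as cyclohexyl, or a pyridyl ring on this carbonyl carbon would help tell these apart. Going by these compounds, it is also open whether the differences seen among the groups on the other carbonyl carbon would hold with butyl in place of phenyl.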